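Adding a Second Methyl to a Pyrazolone Core

The source may hold more compounds than are shown below. What is called first, only, known or untested is meant among the compounds shown, and "the series" means these compounds.

Measured compounds:
compound 1, `CC1=NN(c2ccccc2)C(=O)[C@]12C(=O)C=CC[C@H]2c1ccc(C)cc1`, 2890 nM
compound 2, `CC1=NN(c2ccccc2)C(=O)[C@@]12C(=O)C=CC[C@@H]2c1cccc(C)c1`, 4510 nM
compound 3, `CC1=NN(c2ccccc2)C(=O)[C@@]12C(=O)C=CC[C@@H]2c1ccccc1`, 7770 nM

All three were tested in a functional assay on A549 cells (Homo sapiens) for inhibition, read by MTT assay, with a stated time of 72 h; a higher number here means a weaker inhibitor, a lower number a stronger inhibitor. Compound 3 gives 7770 nM, and compound 2, which carries methyl in place of hydrogen on an aromatic carbon, gives 4510 nM; this is a 1.7-fold lower number from compound 3 to compound 2 (0.24 log units; within the scatter). Compound 1 gives 2890 nM; the difference between its core and that of compound 3 is not broken down here, but its number lies beyond the scatter from the number of compound 3 and within the scatter of compound 2.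

Compound 4, `CC1=NN(c2ccc(C)cc2)C(=O)[C@]12C(=O)C=CC[C@H]2c1ccc(C)cc1`, has not been measured. It differs from compound 1 by methyl in place of hydrogen on an aromatic carbon. This is the same kind of change as that from compound 3 to compound 2, not the same: there the methyl sits meta to a large group, here para to a large group, and the ring it enters is a different one. Because the earlier step was a 1.7-fold lower number from compound 3 to compound 2 (0.24 log units; within the scatter), only a small step is expected from compound 1 to compound 4, a 1.3-fold lower number from compound 1 to compound 4 (0.12 log units; within the scatter). Compound 4 is therefore estimated at 2200 nM, likely between 900 nM and 5500 nM.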

Compound 4, half-maximal inhibitory concentration: 7520 nM
For compound 4 the middle estimate is 3.4-fold (0.53 log units) below the measured one, outside the stated range (above it).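

In this assay the methyl step runs the opposite way on the second core, with a 2.6-fold higher number from compound 1 to compound 4 (0.42 log units; beyond the scatter). Adding a methyl to an aromatic carbon therefore cannot be counted on to act alike across this series, as the two steps set side by side make plain: the same change on two cores in this assay, a 1.7-fold lower number (0.24 log units; within the scatter) from compound 3 to compound 2 and a 2.6-fold higher number (0.42 log units; beyond the scatter) from compound 1 to compound 4, 4.5-fold (0.65 log units) apart, beyond the scatter of two such steps These pairs do not show why the steps part ways: the methyl enters a different ring in each pair, the cores differ as well, and a single pair on each core gives no general rule for other places on these rings.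

The compounds shown leave open whether another small group on these aromatic rings, such as a chlorine atom, a methoxy group or an amine, would also give opposite steps on the two cores. They also leave open whether a longer chain, such as ethyl, in place of the new methyl of compound 4 would go the same way as that methyl.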